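This account rests on a few compounds, and the source may have more. Where it says the series, first, only, none or still open, it means among the compounds named here.

Measured compounds:
compound 1 `CC(C)(C)c1ccc(CN2C(=O)S/C(=C\c3ccc(N)cc3)C2=O)cc1` — 80000 nM
compound 2 `C=C(Br)C(=O)Nc1ccc(/C=C2\SC(=O)N(Cc3cccc(F)c3)C2=O)cc1` — 4000 nM
compound 3 `Nc1ccc(/C=C2\SC(=O)N(Cc3cccc(F)c3)C2=O)cc1` — 121000 nM

In a functional assay on FM3A cells (Mus musculus) for cytotoxicity, read by cell counting, with a stated time of 2 days (on this read-out higher numbers stand for weaker inhibition and lower numbers for stronger inhibition), compound 2 gives the lowest of the three numbers. Compound 1 comes nearest, and compound 3 stands furthest, with a 30-fold higher number from compound 2 to compound 3 (1.48 log units; beyond the scatter) marking the single shown step, a large one, produced by hydrogen in place of (1-bromoethenyl)carbonyl on a nitrogen on an aromatic ring.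

Compound 4 `C=C(Br)C(=O)Nc1ccc(/C=C2\SC(=O)N(CC)C2=O)cc1` keeps that (1-bromoethenyl)carbonyl group and differs from compound 2 only at the ring nitrogen: methyl in place of 3-fluorophenyl on a saturated chain carbon bound to an amide-type nitrogen in a ring. Among the measured compounds shown here, no measured step covers this place. Compounds 1 and 3 carry different groups on the same saturated chain carbon; compound 1 gives 80000 nM and compound 3 gives 121000 nM, two numbers within the usual scatter of each other, so what is known of this part of the molecule points to little movement. Replacing the whole 3-fluorophenyl with methyl is a larger change than that pair shows, and the direction is not fixed by any shown step.

The expectation for compound 4 is therefore a modest loss, with a 2.3-fold higher number from compound 2 to compound 4 (0.35 log units; beyond the scatter) the estimated step, and a wide range. Compound 4 is estimated at 9000 nM in this assay, between 2500 nM and 40000 nM.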

Compound 4, half-maximal inhibitory concentration: 2300 nM
Compound 4: middle estimate off by 3.9-fold (0.59 log units), on the high side; the whole stated range lies above it.
By their numbers in this assay, from the lowest: compounds 4 and 2 (each within the scatter of the next); then compounds 1 and 3 (each within the scatter of the next).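

In this assay, a 1.7-fold lower number from compound 2 to compound 4 (0.24 log units; within the scatter), so 3-fluorobenzyl and ethyl on the ring nitrogen cannot be told apart in this pair while the (1-bromoethenyl)carbonyl group stays in place. The 3-fluorophenyl is therefore not needed for a number in this range: with methyl in its place on the saturated chain carbon bound to an amide-type nitrogen in a ring, compound 4 gives 2300 nM, and the large step in the series remains the one at the other end of the molecule, a 30-fold higher number from compound 2 to compound 3 (1.48 log units; beyond the scatter). Nothing given here bears on why this replacement leaves the read-out within the scatter.

As far as these compounds go, whether a longer chain, or a chain ending in a carboxylic acid or an amine, would also stay within the scatter of compound 2 at this place remains open. Also open is whether the ethyl group would leave the large step intact if hydrogen replaced the (1-bromoethenyl)carbonyl group on the nitrogen, since the compounds shown offer no such pair.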